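Difluoromethyl and Fluorine in Place of Bromine

This account rests on a few compounds, and the source may have more. Where it says the series, first, only, none or still open, it means among the compounds named here.

Compound 1 `NS(=O)(=O)CC(=O)NCCSc1nonc1/C(=N/O)Nc1cccc(C(F)F)c1`: 130 nM
Compound 2 `NS(=O)(=O)CC(=O)NCCSc1nonc1/C(=N/O)Nc1cccc(Br)c1`: 30 nM
Compound 3 `CS(=O)(=O)NCCSc1nonc1/C(=N/O)Nc1ccc(F)c(Br)c1`: 270 nM

In an assay for inhibition of Indoleamine 2,3-dioxygenase 1 (Homo sapiens), read by fluorescence, with a stated time of 1 h (on this read-out lower numbers stand for stronger inhibition and higher numbers for weaker inhibition), compound 2 gives the lowest of the three numbers, with compound 1 nearest and compound 3 furthest. Compound 4 `NS(=O)(=O)CC(=O)NCCSc1nonc1/C(=N/O)Nc1ccc(F)c(C(F)F)c1` differs from compound 2 in one place: 3-(difluoromethyl)-4-fluorophenyl in place of 3-bromophenyl on an amine nitrogen. Among the measured compounds shown here, the one measured step that bears on this is a 4.3-fold lower number from compound 1 to compound 2 (0.64 log units; beyond the scatter), which ran in the opposite direction, bromo replacing difluoromethyl; read backwards it points to a higher number. Compound 3 also carries a fluorine on its ring, but it differs from compound 2 elsewhere as well, so its value shows only that it stands higher. Compound 4 is therefore expected to show a 5.0-fold higher number from compound 2 to compound 4 (0.70 log units; beyond the scatter). The estimate for compound 4 is 150 nM, between 60 nM and 400 nM.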

Compound 4, half-maximal inhibitory concentration: 73 nM
Compound 4: middle estimate off by 2.1-fold (0.31 log units), on the high side, and the stated range covers the measured number.
By their numbers in this assay, from the lowest: compound 2; then compounds 4 and 1 (each within the scatter of the next); then compound 3.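

The two-part swap on the amine nitrogen gives a 2.4-fold higher number from compound 2 to compound 4 (0.39 log units; beyond the scatter) in this assay, so the 3-bromophenyl of compound 2 keeps the lowest number of this series. Fluoro in place of hydrogen on an aromatic carbon gives a 1.8-fold lower number from compound 1 to compound 4 (0.25 log units; within the scatter), which shows that the ring of compound 1 accepts this fluorine without a change that can be told from the scatter. Nothing measured here explains either step.

From the compounds shown here alone, it remains open what fluoro would do on the 3-bromophenyl ring with the chain of compound 2 unchanged. Also open, going by these compounds, is whether chloro or trifluoromethyl in place of the bromo would match compound 2.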